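Swapping the Ketone Aryl Group: From Nitrophenyl to Pyridyl

The source may hold more compounds than are shown below. What is called first, only, known or untested is meant among the compounds shown, and "the series" means these compounds.

Measured so far:
- compound 1, `COc1ccc(-c2cc3ccccc3nc2/C=C/C(=O)c2ccc(OC)c(OC)c2)cc1`, gives 8860 nM in a functional assay on A549 cells (Homo sapiens) for antiproliferative activity, read by XTT assay, with a stated time of 72 h; on this read-out lower numbers stand for stronger inhibition and higher numbers for weaker inhibition
- compound 2, `COc1ccc(-c2cc3ccccc3nc2/C=C/C(=O)c2ccc(N)cc2)cc1`, gives 7530 nM in this assay
- compound 3, `COc1ccc(-c2cc3ccccc3nc2/C=C/C(=O)c2ccc([N+](=O)[O-])cc2)cc1`, gives 6310 nM in this assay

Compound 3 carries the lowest of the three numbers, but the steps of a 1.2-fold lower number from compound 2 to compound 3 (0.08 log units; within the scatter) and a 1.4-fold lower number from compound 1 to compound 3 (0.15 log units; within the scatter) are both within the scatter, so no order among the three can be drawn. The next compound, compound 4, is `COc1ccc(-c2cc3ccccc3nc2/C=C/C(=O)c2ccccn2)cc1`. It differs from compound 3 in one place: pyridin-2-yl in place of 4-nitrophenyl on a carbonyl carbon. All three measured steps bear on this change, since each swaps the group on the same carbonyl carbon: a 1.2-fold lower number from compound 1 to compound 2 (0.07 log units; within the scatter), a 1.4-fold lower number from compound 1 to compound 3 (0.15 log units; within the scatter) and a 1.2-fold lower number from compound 2 to compound 3 (0.08 log units; within the scatter), none reaching beyond the scatter. Three different aryl groups at this position, ranging from electron-rich to amino to nitro, gave numbers that cannot be told apart, and nothing among them points to a shift for a pyridin-2-yl. The expected step is therefore a 1.2-fold higher number from compound 3 to compound 4 (0.08 log units; within the scatter), with no direction beyond the scatter. Compound 4 is estimated at 7500 nM in this assay, with a range from 2500 nM to 25000 nM.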

Compound 4, half-maximal inhibitory concentration: 6140 nM
Compound 4: middle estimate off by 1.2-fold (0.09 log units), on the high side; the measured number falls inside the stated range.
By their numbers in this assay, from the lowest: compounds 4, 3, 2 and 1 (each within the scatter of the next).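

In this assay, a ring with a hetero atom on this carbonyl carbon behaves like the carbon-only aryl rings before it: the pyridin-2-yl gives a 1.0-fold lower number from compound 3 to compound 4 (0.01 log units; within the scatter), a 1.2-fold lower number from compound 2 to compound 4 (0.09 log units; within the scatter) and a 1.4-fold lower number from compound 1 to compound 4 (0.16 log units; within the scatter). The range of groups at this place now runs beyond substituted phenyl rings, yet all four compounds still give numbers that cannot be told apart. No measurement is at hand that would say why this swap leaves the number where it was.

From the compounds shown here alone, whether any group on this carbonyl carbon can move the number beyond the scatter remains open, for instance a saturated ring such as cyclohexyl or a phenyl bearing a carboxylic acid. Also open, going by these compounds, is what a change on the shared core would do, such as a hydroxyl in place of its methoxy group.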